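Chloro for hydrogen on the aryl ring, two cores

This account rests on a few compounds, and the source may have more. Where it says the series, first, only, none or still open, it means among the compounds named here.

Compound 1 `Cc1nc(-c2ccccc2)sc1C(=O)CSc1nc(N)c(C#N)c(-c2ccc(Cl)cc2)n1` in a functional assay on U-87MG ATCC cells for antiproliferative activity against U-87 MG (Homo sapiens), read by MTT assay, with a stated time of 48 h, tested at 50 uM (a lower number here means a stronger effect, a higher number a weaker effect of the compound at the concentration tested), gives 44.3%. Compound 2 `COc1ccc(-c2nc(SCC(=O)c3sc(-c4ccccc4)nc3C)[nH]c(=O)c2C#N)cc1OC` gives 21.4% in this assay, and compound 3 `COc1ccc(-c2nc(SCC(=O)c3sc(-c4ccc(Cl)cc4)nc3C)[nH]c(=O)c2C#N)cc1OC` gives 59.8%. From compound 2 to compound 3 the change is chloro in place of hydrogen on an aromatic carbon, and the measured step is a number 38.4 percentage points higher from compound 2 to compound 3 (beyond the scatter), a weaker effect. Compound 4 `Cc1nc(-c2ccc(Cl)cc2)sc1C(=O)CSc1nc(N)c(C#N)c(-c2ccc(Cl)cc2)n1` is not yet measured in this assay; it differs from compound 1 by chloro in place of hydrogen on an aromatic carbon, the same change at the same place. The difference between the cores of compound 1 and compound 2 is not broken down here. Going by the values given here, only one measured example of this change exists, and that on another core. Because the step from compound 2 to compound 3 is a number 38.4 percentage points higher from compound 2 to compound 3 (beyond the scatter), a step of the same direction but smaller size is expected for compound 4, namely a number 23.7 percentage points higher from compound 1 to compound 4 (beyond the scatter). Compound 4 is therefore estimated at 68%, expected between 45% and 92%.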

Compound 4, a percentage reported as activity, at one concentration (the size of the read-out at that concentration, not a potency): 15.5%
Beside the measured number, compound 4's estimate is 52.5 percentage points above it, outside the stated range (below it).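

On the core of compound 1, phenyl to 4-chlorophenyl gives a number 28.8 percentage points lower from compound 1 to compound 4 (beyond the scatter) in this assay and so a stronger effect, whereas on the core of compound 2 the same change gives a weaker one. The change therefore does not carry over between these two cores in size or direction: the same change on two cores in this assay, a number 38.4 percentage points higher (beyond the scatter) from compound 2 to compound 3 and a number 28.8 percentage points lower (beyond the scatter) from compound 1 to compound 4, 67.2 percentage points apart, beyond the scatter of two such steps. Going by these compounds alone, with only one pair on each core, this shows that a step measured on one of these cores cannot be transferred to the other, but it does not show which difference between the cores matters or how a further core would respond.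

Open, going by these compounds, is whether a bromo, methoxy or amine group at the same place would follow chloro on either core. Also open, on these data alone, is whether either opposite step would hold for those groups.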